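Tert-butyl for acetamido on the shared core

The compounds below may be only part of what the source reports. "The series", "measured", "known", "first", "only" and "open" are said of these compounds alone.

Measured so far:
compound 1 `CC(C)(C)c1ccc(-n2c(-c3cccnc3N)nc3cc(Br)cnc32)cc1`: 0.9 degrees C
compound 2 `CC(=O)Nc1ccc(-n2c(-c3cccnc3N)nc3cccnc32)cc1`: 3.7 degrees C

In an in vitro assay on Sf9 cells for binding affinity to RAC-alpha serine/threonine-protein kinase (Homo sapiens), tested at 30 uM (on this read-out higher numbers stand for stronger stabilisation of the target against heat and lower numbers for weaker stabilisation of the target), compound 2 stands highest of the two numbers; compound 1 comes out lower, a gap beyond the scatter. Compound 3 `CC(C)(C)c1ccc(-n2c(-c3cccnc3N)nc3cccnc32)cc1` is compound 2 with tert-butyl in place of acetamido on an aromatic carbon. Going by the values given here, no direct step with this change has been measured. A drop beyond the scatter is expected, since the tert-butyl-bearing compound 1 gives 0.9 degrees C in this assay, though it also differs on the core. Compound 3 is estimated at 1.2 degrees C, range 0 degrees C to 2.8 degrees C, an expected step of a number 2.5 degrees C lower from compound 2 to compound 3 (beyond the scatter).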

Compound 3, shift of the target's melting temperature: 1.9 degrees C
For compound 3 the middle estimate is 0.70 degrees C below the measured one; the range from low to high includes it.
By their numbers in this assay, from the lowest: compounds 1 and 3 (each within the scatter of the next); then compound 2.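

In this assay, tert-butyl in place of acetamido on this aromatic carbon, para to a large group, gives a number 1.8 degrees C lower from compound 2 to compound 3 (beyond the scatter), a first direct read of this change on the shared core. Hydrogen in place of bromo on an aromatic carbon gives a number 1.0 degrees C higher from compound 1 to compound 3 (within the scatter), so the bromo does not separate the two tert-butyl compounds.

From the compounds shown here alone, whether an amine or a carboxylic acid at the acetamido position would match compound 2 remains open, as does the effect of a longer chain on the amide carbonyl. No supporting data explain the step from acetamido to tert-butyl.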